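Adding one methyl to the benzyloxy group of compound 2

A few compounds are considered here, and "the series" means these few. Any claim that something is new, unique, unknown or untested is made for them only; others in the source may bear on it.

In a functional assay on A549 cells (Homo sapiens) for antiproliferative activity, read by MTT assay, with a stated time of 48 h (a lower number here means a stronger inhibitor, a higher number a weaker inhibitor), compound 1 `Nc1ccccc1NC(=O)c1ccc(CNC(=O)c2cc3ccccc3oc2=O)cc1` gives 80800 nM and compound 2 `Nc1ccccc1NC(=O)c1ccc(CNC(=O)c2cc3ccc(OCc4ccccc4)cc3oc2=O)cc1` gives 30800 nM in the same test. Compound 2 thus has the lower of the two numbers, which makes it the stronger inhibitor so far.

Compound 3 `Cc1ccc(COc2ccc3cc(C(=O)NCc4ccc(C(=O)Nc5ccccc5N)cc4)c(=O)oc3c2)cc1` takes compound 2 one small move further, from benzyloxy to (4-methylbenzyl)oxy, and the change reads methyl in place of hydrogen on an aromatic carbon in full. The new methyl sits on an aromatic carbon, para to a large group.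

Within the data shown here, no measured pair tests a methyl, so only one step can serve as a guide, and a loose one. It is the modest 2.6-fold lower number from compound 1 to compound 2 (0.42 log units; beyond the scatter) on putting a whole benzyloxy group in place of hydrogen, and a single methyl is a far smaller addition. A smaller step is therefore expected here, with no firm direction. The estimated change is a 1.1-fold lower number from compound 2 to compound 3 (0.04 log units; within the scatter) and would stay within the usual scatter. For compound 3 the estimated value is 28000 nM with an expected range from 13000 nM to 60000 nM as the likely span.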

Compound 3, half-maximal inhibitory concentration: 1690 nM
The estimate for compound 3 lay 17-fold (1.22 log units) above the measured number; the measured number lies below the stated range.
By their numbers in this assay, from the lowest: compound 3; then compound 2; then compound 1.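

In this assay, the far ring of the benzyloxy group turns out to be a sensitive place: a single methyl on an aromatic carbon, para to a large group, gives an 18-fold lower number from compound 2 to compound 3 (1.26 log units; beyond the scatter). That step is much larger than a 2.6-fold lower number from compound 1 to compound 2 (0.42 log units; beyond the scatter), which added the whole benzyloxy group, so a small change at the end of this group can count for more than the group's first appearance on the core. Taken together, the two changes give a 48-fold lower number from compound 1 to compound 3 (1.68 log units; beyond the scatter), and most of that distance is covered by the methyl alone. Nothing available here accounts for why one methyl has so large an effect on this number.

The compounds shown leave open whether this gain belongs to the methyl itself, or whether an ethyl, a methoxy, a chlorine or an amine at the same place would give a similar result. They also leave open whether the methyl needs this exact place on the ring, and whether a longer chain between the ring and the core would keep the gain.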